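Methyl to isopropyl in an antiproliferative series

The source may report more compounds than this note shows. Statements on the series, on what has been measured and on what is new or still open speak of the compounds shown alone.

In a functional assay on PC-3 cells (Homo sapiens) for antiproliferative activity, read by MTT assay, with a stated time of 24 h (on this read-out lower numbers stand for stronger inhibition and higher numbers for weaker inhibition), compound 1 (`CCn1c(C(=O)N[C@H](C)C(=O)OC)ccc1C(CC)(CC)c1ccc(OCS(=O)(=O)c2ccccc2)c(C)c1`) reaches only a limit, > 50000 nM, as the limit of > 50000 nM in this assay, at which 1 of the 3 values shown sits, records. Compound 2 (`CCn1c(C(=O)N[C@@H](CC(=O)OC)C(=O)OC)ccc1C(CC)(CC)c1ccc(OCS(=O)(=O)c2ccccc2)c(C)c1`) gives 6490 nM. Compound 3 (`CCn1c(C(=O)N[C@@H](C)CO)ccc1C(CC)(CC)c1ccc(OCS(=O)(=O)c2ccccc2)c(C)c1`) gives 9520 nM, so it stands level with compound 2 given a 1.5-fold higher number from compound 2 to compound 3 (0.17 log units; within the scatter).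

The next change, to compound 4 (`CCn1c(C(=O)N[C@H](CO)C(C)C)ccc1C(CC)(CC)c1ccc(OCS(=O)(=O)c2ccccc2)c(C)c1`), is isopropyl in place of methyl on a saturated chain carbon bound to an amide-type nitrogen and a saturated chain carbon. Among the measured compounds shown here, no measured step varies this group alone. The nearest are an at least 7.7-fold lower number from compound 1 to compound 2 (0.88 log units; beyond the scatter) and an at least 5.2-fold lower number from compound 1 to compound 3 (0.72 log units; beyond the scatter), both starting from a limit, so they show only that this substituent can matter.

The expected change is no step beyond the scatter, estimated as a 1.1-fold lower number from compound 3 to compound 4 (0.02 log units; within the scatter). For compound 4, the estimated value in this assay is 9000 nM, within an expected range of 3000 nM to 30000 nM.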

Compound 4, half-maximal inhibitory concentration: 7300 nM
Beside the measured number, compound 4's estimate is 1.2-fold (0.09 log units) above it; low and high end bracket the measured number.
By their numbers in this assay, from the lowest: compounds 2, 4 and 3 (each within the scatter of the next). At a limit, above all of these: compound 1.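

With isopropyl in place of methyl, this assay records a 1.3-fold lower number from compound 3 to compound 4 (0.12 log units; within the scatter), so this carbon accepts the larger group without a step beyond the scatter. The 1-(hydroxymethyl)-2-methylpropyl group on the amide-type nitrogen stands level with 1,2-bis(methoxycarbonyl)ethyl, with a 1.1-fold higher number from compound 2 to compound 4 (0.05 log units; within the scatter), while against 1-(methoxycarbonyl)ethyl it gives an at least 6.8-fold lower number from compound 1 to compound 4 (0.83 log units; beyond the scatter). That last step starts from a limit, which compound 1 remains: the limit of > 50000 nM in this assay, at which 1 of the 4 values shown sits.

Going by these compounds, whether a phenyl or a tert-butyl group on this carbon would hold the same level stays open. So does the outcome of a carboxylic acid in place of the hydroxymethyl group.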